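Lengthening the ether chain of compound 3

A few compounds are considered here, and "the series" means these few. Any claim that something is new, unique, unknown or untested is made for them only; others in the source may bear on it.

Measured so far in a functional assay on A-431 cells (Homo sapiens) for inhibition, with a stated time of 72 h; a higher number here means a weaker inhibitor, a lower number a stronger inhibitor:
- compound 1 `Oc1c(CN2CCCC2)cc(Cl)c2cccnc12`: 7410 nM
- compound 2 `COCc1cc(CN2CCCC2)c(O)c2ncccc12`: 52500 nM
- compound 3 `COCc1cc(CN2CCCCC2)c(O)c2ncccc12`: 22400 nM

Compound 3 stands in the middle of this small set, with a lower number than compound 2 and a higher one than compound 1. Both gaps lie beyond the usual scatter. The next compound, compound 4 `CCCOCc1cc(CN2CCCCC2)c(O)c2ncccc12`, differs from it in one place: ethyl in place of hydrogen on a saturated chain carbon bound to an oxygen on a saturated carbon. Methoxymethyl thus becomes propoxymethyl.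

Within the data shown here, no measured step makes this exact change, so the evidence is indirect. The closest is a 7.1-fold higher number from compound 1 to compound 2 (0.85 log units; beyond the scatter), which shows that replacing chloro with methoxymethyl can shift the number. The other is a 2.3-fold lower number from compound 2 to compound 3 (0.37 log units; beyond the scatter), a swap of pyrrolidin-1-yl for piperidin-1-yl that lowered the number. Both steps are modest, so a modest step toward a lower number is expected in this assay, though the direction is uncertain. The expected step is a 2.2-fold lower number from compound 3 to compound 4 (0.35 log units; beyond the scatter). For compound 4 the estimated value is 10000 nM, with an expected range from 4000 nM to 30000 nM.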

Compound 4, half-maximal inhibitory concentration: 6760 nM
Compound 4: middle estimate off by 1.5-fold (0.17 log units), on the high side, and the stated range covers the measured number.
By their numbers in this assay, from the lowest: compounds 4 and 1 (each within the scatter of the next); then compound 3; then compound 2.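

Replacing methoxymethyl with propoxymethyl gives a 3.3-fold lower number from compound 3 to compound 4 (0.52 log units; beyond the scatter) in this assay, so adding ethyl at this saturated chain carbon lowers the number rather than raising it. The earlier steps shown here changed the whole group on the aromatic carbon or the amine ring, whereas this one changes only the length of the ether chain while the piperidin-1-yl group stays fixed. Chain length therefore matters here on its own, at least between these two compounds, and no data shown here bear on the cause of the drop. The compounds shown leave open whether a longer chain such as butoxymethyl would lower the number further, or whether an amine at the chain end would keep the drop. They also leave open whether the same lengthening would lower the number with pyrrolidin-1-yl in place of piperidin-1-yl.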